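Methoxy for methylamino on a thienopyrimidine solubility series

The source may hold more compounds than are shown below. What is called first, only, known or untested is meant among the compounds shown, and "the series" means these compounds.

Measured so far in a physicochemical assay for solubility, at pH 2; on this read-out higher numbers stand for higher solubility and lower numbers for lower solubility:
Compound 1 `CNc1nc(NCCCN(C)C)c2sc(-c3ccc(C(F)(F)F)cc3)cc2n1` gives 240 ug/mL.
Compound 2 `CNc1nc(N2CCC(N)CC2)c2sc(-c3ccc(C(F)(F)F)cc3)cc2n1` gives > 200 ug/mL, which is a limit of the assay rather than a number.
Compound 3 `CNc1nc(Nc2cccc(C(N)=O)c2)c2sc(-c3ccc(C(F)(F)F)cc3)cc2n1` gives 85 ug/mL.

Among the numbers shown, compound 1 stands highest, with compound 3 nearest at a 2.8-fold lower number from compound 1 to compound 3 (0.45 log units; beyond the scatter). The step from compound 2 to compound 3 is an at least 2.3-fold lower number from compound 2 to compound 3 (0.37 log units; beyond the scatter), and the step from compound 1 to compound 2 cannot be sized, since compound 2 sits at the limit of > 200 ug/mL in this assay, at which 1 of the 3 values shown sits.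

Compound 4 `COc1nc(NCCCN(C)C)c2sc(-c3ccc(C(F)(F)F)cc3)cc2n1` differs from compound 1 by methoxy in place of methylamino on an aromatic carbon. Among the measured compounds shown here, none of the measured steps touches this position: all three change the other substituent on the shared core, and the two readable ones were modest. The change here is small in atom count and leaves the (3-(dimethylamino)propyl)amino group untouched. A step in this assay no larger than those modest ones is therefore expected, most likely a slight decrease or none beyond the scatter. Compound 4 is estimated at 150 ug/mL, between 60 ug/mL and 400 ug/mL, meaning an expected step of a 1.6-fold lower number from compound 1 to compound 4 (0.20 log units; within the scatter).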

Compound 4, solubility: 214 ug/mL
Compound 4: the middle estimate sits 1.4-fold (0.15 log units) below what was measured, within the range that was stated.
By their numbers in this assay, from the lowest: compound 3; then compounds 4 and 1 (each within the scatter of the next).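

In this assay, among the compounds shown here, every earlier step changed the other substituent on the shared core, so this is the first view of the group on the aromatic carbon between two ring nitrogen atoms. Methoxy in place of methylamino there, which gives up the hydrogen-bond donor of methylamino, comes with a 1.1-fold lower number from compound 1 to compound 4 (0.05 log units; within the scatter), so in this one pair the two groups cannot be told apart on this read-out. Nothing shown accounts for this result.

On these data alone, it remains open whether the same swap would read the same way with 4-aminopiperidin-1-yl or (3-carbamoylphenyl)amino as the other substituent. Also open, as far as these compounds go, is what a different group at this place, such as ethoxy, dimethylamino or a plain hydrogen, would do to the number.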